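A few compounds are considered here, and "the series" means these few. Any claim that something is new, unique, unknown or untested is made for them only; others in the source may bear on it.

Measured compounds:

- Compound 1 `N#Cc1ccc(-n2cc(-c3n[nH]c4cc(Cl)c(N[C@@H]5CCNC5)cc34)cn2)cc1`: 700 nM
- Compound 2 `CC(C)Nc1ccc2c(-c3cnn(C)c3)n[nH]c2c1`: 46600 nM
- Compound 3 `Cn1cc(-c2n[nH]c3ccc(-c4ccccc4)cc23)cn1`: 620 nM

In an assay on isolated protein for inhibition of tyrosine-protein kinase receptor UFO (Homo sapiens), with a stated time of 1.5 h (on this read-out higher numbers stand for weaker inhibition and lower numbers for stronger inhibition), compound 1 gives 700 nM. Among the three numbers it sits second highest. Compound 3 is the nearest, with its value of 620 nM within the scatter of compound 1, so no order between the two can be read. Compound 2, at 46600 nM, is the furthest off and stands well beyond the scatter, a much higher number than compound 1.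

Compound 4 `Clc1cc2[nH]nc(-c3cnn(-c4ccccc4)c3)c2cc1N[C@@H]1CCNC1` has not been measured. It differs from compound 1 in one place: hydrogen in place of cyano on an aromatic carbon, on a six-membered aromatic ring of carbon only, para to a large group. Cut one bond further out, the change reads 4-cyanophenyl to phenyl.

Going by the values given here, no measured pair in this set isolates this change, so the size of the step in this assay cannot be read from the data. The loss of the cyano group is expected to give a modest rise in the number, roughly at the edge of the scatter, a 2.1-fold higher number from compound 1 to compound 4 (0.33 log units; beyond the scatter). For compound 4 the expected value is 1500 nM, with a range from 400 nM to 6000 nM.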

Compound 4, half-maximal inhibitory concentration: 1700 nM
Estimate against measurement, compound 4: 1.1-fold (0.05 log units) below; the measured number falls inside the stated range.
By their numbers in this assay, from the lowest: compounds 3 and 1 (each within the scatter of the next); then compound 4; then compound 2.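

In this assay, going by these compounds alone, this pair gives the first direct reading of the place para to a large group on the six-membered aromatic ring: hydrogen in place of cyano on an aromatic carbon gives a 2.4-fold higher number from compound 1 to compound 4 (0.39 log units; beyond the scatter). The step is modest but lies beyond the scatter, so on this one pair the nitrile goes with the lower number, while its removal still leaves a value on the same read-out. Nothing available accounts for the size or direction of this step, so it stands as an observation only.

Still open, from the compounds shown here alone, is whether a fluorine, a methoxy group, a carboxylic acid or an aminomethyl group at this same place would give a number close to that of the nitrile, close to that of the hydrogen, or outside both. Also open, going by these compounds, is whether the step carries over to other parts of the series, since the remaining compounds differ from this pair in more than one place and offer no second reading of 4-cyanophenyl to phenyl.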